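The compounds below may be only part of what the source reports. "The series", "measured", "known", "first", "only" and "open" are said of these compounds alone.

Of the compounds shown here, three built on a shared core have been tested in a functional assay on K562 cells (Homo sapiens) for cytotoxicity, read by MTT assay, with a stated time of 24 h; on this read-out lower numbers stand for stronger inhibition and higher numbers for weaker inhibition. Compound 1 (`COc1ccc(/C=C2\CN(C)C/C(=C\c3ccccc3F)C2=O)cc1`) gives 18400 nM, compound 2 (`COc1cc(/C=C2\CN(C)C/C(=C\c3ccccc3F)C2=O)cc(OC)c1`) gives 6320 nM, and compound 3 (`COc1cc(/C=C2\CN(C)C/C(=C\c3cc(OC)c(OC)c(OC)c3)C2=O)cc(OC)c1`) gives 3470 nM. Compound 3 stands level with compound 2, since the two lie within the usual scatter of each other, while compound 1 gives a higher number than compound 3, a gap beyond the scatter.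

The next compound, compound 4 (`COc1cc(/C=C2\CN(C)C/C(=C\c3ccc(C#N)cc3)C2=O)cc(OC)c1OC`), departs from compound 3 in one place, with 4-cyanophenyl in place of 3,5-dimethoxyphenyl on a double-bonded chain carbon bound to a double-bonded ring carbon. For the measured compounds named here, no two measured compounds differ in only one place, so the effect of a single change has not been observed here. The three measured values all fall in a fairly narrow band, and no large move is expected. The expected change, a 1.4-fold higher number from compound 3 to compound 4 (0.16 log units; within the scatter), is not expected to go beyond the scatter. For compound 4 the estimated value in this assay is 5000 nM, with an expected range from 1500 nM to 16000 nM.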

Compound 4, half-maximal inhibitory concentration: 4290 nM
Estimate against measurement, compound 4: 1.2-fold (0.07 log units) above; the measured number falls inside the stated range.
By their numbers in this assay, from the lowest: compounds 3, 4 and 2 (each within the scatter of the next); then compound 1.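

In this assay the step from 3,5-dimethoxyphenyl to 4-cyanophenyl, on a double-bonded chain carbon bound to a double-bonded ring carbon, gives a 1.2-fold higher number from compound 3 to compound 4 (0.09 log units; within the scatter) and so leaves the two compounds level. For the compounds shown here, this is the first comparison in which only one place differs, and it shows that at this position, with the rest of compound 3 held fixed, the nitrile-bearing ring and the dimethoxy-bearing ring cannot be told apart on this read-out. No measurement at hand accounts for this parity between the two groups.

As far as these compounds go, whether an unsubstituted phenyl, a ring bearing an amine or a ring bearing a carboxylic acid would also read level at this position remains open. So does whether the same exchange would give a similar result with the rest of the molecule changed.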